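The source may report more compounds than this note shows. Statements on the series, on what has been measured and on what is new or still open speak of the compounds shown alone.

Two esters built on the same shared core have been tested in a functional assay on the whole organism (strain Kunming) with Mus musculus as the target, with a stated time of 0.5 h, at a dose of 300 mg/kg by the intraperitoneal route; on this read-out higher numbers stand for a weaker effect at the one dose given and lower numbers for a stronger effect. Compound 1, `COc1cc(OC)c(OC)cc1/C=C/COC(=O)/C=C/c1ccc(OC)c(OC)c1`, gives 75% in this assay. Compound 2, `COc1cc(OC)c(OC)cc1/C=C/COC(=O)/C=C/c1cc(OC)c(OC)c(OC)c1OC`, gives 50% in this assay. Among the measured compounds shown here, compound 2 therefore stands lowest of the two numbers; its only neighbour is compound 1, whose number is higher by a gap beyond the usual scatter, so compound 2 shows the stronger effect at this dose. Compound 3, `COc1cc(OC)c(OC)cc1/C=C/COC(=O)/C=C/c1ccc(OC)c(OC)c1OC`, has not yet been measured. It differs from compound 2 by hydrogen in place of methoxy on an aromatic carbon, so compound 3 keeps part of the methoxy pattern of compound 2 and loses part of it, moving in the direction of compound 1. For the measured compounds named here, no step between two measured compounds that share this single change has been recorded, so any expectation rests on the two values alone. Since compound 1, with fewer methoxy groups, gives 75%, a modest weakening in this assay is expected, a number 10 percentage points higher from compound 2 to compound 3 (within the scatter). Compound 3 is estimated at 60%, within a range from 45% to 75%.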

Compound 3, a percentage reported as activity, at one dose (the size of the read-out at that dose, not a potency): 75%
For compound 3 the middle estimate is 15 percentage points below the measured one; the measured number falls inside the stated range.
By their numbers in this assay, from the lowest: compound 2; then compounds 1 and 3 (each within the scatter of the next).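

In this assay, replacing the methoxy that sits para to a methoxy group and meta to a large group with hydrogen gives a number 25 percentage points higher from compound 2 to compound 3 (beyond the scatter) at the one dose tested, so the stronger effect of compound 2 goes with the methoxy on this aromatic carbon. The other step, with methoxy in place of hydrogen on an aromatic carbon, gives no change at the digits printed from compound 1 to compound 3 (within the scatter) and so shows that adding a methoxy to this ring does not by itself strengthen the effect; compound 2 is the only one of the three that stands apart. No measurement shown here explains why this one methoxy matters.

Going by these compounds, it remains open whether a methoxy is specifically needed on this carbon, or whether an ethoxy group, a hydroxyl group, a fluorine atom or an amine there would give a similar number. Since each compound is represented by a single read-out at one dose, the compounds shown also leave open how the gap between compound 2 and compound 3 would look at other doses or at other times.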